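A few compounds are considered here, and "the series" means these few. Any claim that something is new, unique, unknown or untested is made for them only; others in the source may bear on it.

Measured so far in a functional assay on MIA PaCa-2 cells (Homo sapiens) for antiproliferative activity, read by sulforhodamine B assay, with a stated time of 48 h; on this read-out higher numbers stand for weaker inhibition of growth and lower numbers for stronger inhibition of growth:
- compound 1, `O=C(NCc1cn(Cc2ccc(F)cc2)nn1)c1cn(-c2ccccc2)nc1-c1ccccc1`: compound 1 gives 9600 nM
- compound 2, `O=C(NCc1cn(Cc2ccc(Cl)cc2)nn1)c1cn(-c2ccccc2)nc1-c1ccccc1`: compound 2 gives 8700 nM
- compound 3, `O=C(NCc1cn(Cc2ccc(F)cc2)nn1)c1cn(-c2ccccc2)nc1-c1ccc(F)cc1`: compound 3 gives 14300 nM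

Compound 3 carries the highest of the three numbers, but the step of a 1.5-fold higher number from compound 1 to compound 3 (0.17 log units; within the scatter) is within the scatter, and the value of compound 2 lies no further from it than that, so the three compounds cannot be ordered on these numbers.

Compound 4, `O=C(NCc1cn(Cc2ccc(Cl)cc2)nn1)c1cn(-c2ccccc2)nc1-c1ccc(F)cc1`, is compound 3 with one change: chloro in place of fluoro on an aromatic carbon. The same exchange, 4-fluorobenzyl to 4-chlorobenzyl, has been measured once already in this series, on the pair without the fluoro on the other phenyl ring, where a 1.1-fold lower number from compound 1 to compound 2 (0.04 log units; within the scatter) was observed. Among the compounds with values here, that single precedent gives no step beyond the scatter, and no other measured pair bears on the change. For compound 4 the expected step is therefore a 1.1-fold lower number from compound 3 to compound 4 (0.04 log units; within the scatter), with no direction claimed beyond the scatter. The estimate for compound 4 in this assay is 13000 nM, with a range from 6000 nM to 28000 nM.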

Compound 4, concentration for 50% growth inhibition: 280 nM
The estimate for compound 4 lay 46-fold (1.67 log units) above the measured number; measured number below the stated range.
By their numbers in this assay, from the lowest: compound 4; then compounds 2, 1 and 3 (each within the scatter of the next).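

In this assay, 4-chlorobenzyl in place of 4-fluorobenzyl gives a 51-fold lower number from compound 3 to compound 4 (1.71 log units; beyond the scatter), so this exchange does not stay as silent as it did on the earlier pair: the same change on two cores in this assay, a 1.1-fold lower number (0.04 log units; within the scatter) from compound 1 to compound 2 and a 51-fold lower number (1.71 log units; beyond the scatter) from compound 3 to compound 4, 46-fold (1.67 log units) apart, beyond the scatter of two such steps

Fluoro in place of hydrogen on the other phenyl ring likewise gives a 31-fold lower number from compound 2 to compound 4 (1.49 log units; beyond the scatter), although the same change moved nothing beyond the scatter on the core of compound 1: the same change on two cores in this assay, a 1.5-fold higher number (0.17 log units; within the scatter) from compound 1 to compound 3 and a 31-fold lower number (1.49 log units; beyond the scatter) from compound 2 to compound 4, 46-fold (1.67 log units) apart, beyond the scatter of two such steps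

Neither change has a size of its own in these compounds: the large drop in the number appears only in compound 4, where 4-chlorobenzyl and 4-fluorophenyl stand together.

From the compounds shown here alone, the whole effect rests on compound 4 alone, so it remains open whether it is specific to this pair of halogens. A bromo or methyl group in place of the chloro, or a chloro or methoxy group in place of the fluoro on the 4-fluorophenyl group, would show how far it extends.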